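The source may report more compounds than this note shows. Statements on the series, on what has been measured and on what is new or still open speak of the compounds shown alone.

Compound 1, `CCOC(=O)CCO/N=C(/c1ccc(OC)c(OC)c1OC)c1cccc2ccccc12`: > 20000 nM
Compound 2, `CCOC(=O)C(C)C(O)(c1ccc(OC)c(OC)c1OC)c1cccc2ccccc12`: > 20000 nM
Compound 3, `COc1ccc(C(c2ccc(OCCO)cc2)c2cccc3ccccc23)c(OC)c1OC`: > 20000 nM

In a functional assay on MCF7 cells (Homo sapiens) for inhibition, read by sulforhodamine B assay, with a stated time of 48 h (on this read-out higher numbers stand for weaker inhibition and lower numbers for stronger inhibition), compound 1 reaches only a limit of the assay, > 20000 nM, not a number. Compound 2 likewise stops at a limit, > 20000 nM. Compound 3 also gives a limit, > 20000 nM. Compound 1 therefore stands where every measured compound stands, because of the limit of > 20000 nM in this assay, at which 3 of the 3 values shown sit.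

Compound 4, `CCOC(=O)CO/N=C(/c1ccc(OC)c(OC)c1OC)c1cccc2ccccc12`, differs from compound 1 in one place: ethoxycarbonyl in place of (ethoxycarbonyl)methyl on a saturated chain carbon bound to an oxygen on an unsaturated carbon. Among the measured compounds shown here, no measured step shows what such a shortening does here, so in this assay no change beyond the scatter is expected, and the likeliest outcome is that compound 4 again returns only a limit. Compound 4 is estimated at 30000 nM, with a range from 10000 nM to 100000 nM, which means an expected step that the limit leaves unreadable from compound 1 to compound 4.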

Compound 4, half-maximal inhibitory concentration: > 20000 nM
Compound 4 ended at the assay's limit (the forecaster's own chance of this, stated with the estimate: 75%); the middle value does not contradict the limit.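

Compound 1 and compound 4 both stop at a limit in this assay, so no step between them can be read: the limit of > 20000 nM in this assay, at which 4 of the 4 values shown sit.

The compounds shown leave open which change, if any, would bring a real number in this assay.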